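Drawing a Configuration: Compound 3 to Compound 4

The source may hold more compounds than are shown below. What is called first, only, known or untested is meant among the compounds shown, and "the series" means these compounds.

Measured compounds in a physicochemical assay for lipophilicity, read by HPLC, measured as chromatographic lipophilicity, at pH 7.4; on this read-out lower numbers stand for lower lipophilicity and higher numbers for higher lipophilicity:
compound 1 `O=C(C1CCN(c2ccncn2)CC1)N1N=CC[C@H]1c1ccccc1` gives 3.2;
compound 2 `Cc1nnc(N2CCC(C(=O)N3N=CC[C@H]3c3ccccc3)CC2)o1` gives 3.2;
compound 3 `O=C(C1CCN(c2ccccc2)CC1)N1N=CCC1c1ccccc1` gives 6.3.

Compound 3 stands highest of the three measured numbers, beyond the scatter above both compound 1 and compound 2, which sit within the scatter of each other. Among the measured compounds shown here, the only measured step between neighbours, no change at the digits printed from compound 1 to compound 2 (within the scatter), exchanges one ring on an amine nitrogen for another and moves nothing.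

Compound 4 `O=C(C1CCN(c2ccccc2)CC1)N1N=CC[C@H]1c1ccccc1` differs from compound 3 only in this way: the two compounds have the same atoms and bonds; at least one stereo element is drawn with a configuration in one of them and without one in the other: 1 of 1 stereo elements differ; a stereocentre at a saturated ring carbon is drawn without a configuration in compound 3 and S in compound 4. For the measured compounds named here, no measured step bears on such a change, since none of the three measured compounds differs from another only in how a stereocentre is drawn. With the same atoms and bonds present in both, the read-out of this assay has no reason to move, and the expected step from compound 3 to compound 4 is no change at the digits printed from compound 3 to compound 4 (within the scatter), within the scatter. Compound 4 is therefore estimated at 6.3, expected to fall between 6 and 6.6.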

Compound 4, distribution coefficient: 6.3
Beside the measured number, compound 4's estimate shows no gap at the digits printed; the measured number falls inside the stated range.
By their numbers in this assay, from the lowest: compounds 1 and 2 (each within the scatter of the next); then compounds 3 and 4 (each within the scatter of the next).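

In this assay there is no change at the digits printed from compound 3 to compound 4 (within the scatter) when the stereocentre at the saturated ring carbon is drawn as S, and the pair differs only in this: the fact that one of compounds 3 and 4 is drawn with a defined configuration and the other without, at the place where they differ.

Compound 4 is drawn with the same configuration as compounds 1 and 2, so the ring on the amine nitrogen can now be compared as a change in one place. Phenyl in place of pyrimidin-4-yl gives a number 3.10 log units higher from compound 1 to compound 4 (beyond the scatter) and phenyl in place of 5-methyl-1,3,4-oxadiazol-2-yl gives a number 3.10 log units higher from compound 2 to compound 4 (beyond the scatter) on that single change.

The compounds shown leave open where other groups on that nitrogen would fall, such as pyridin-3-yl or a phenyl carrying a carboxylic acid or an amine. They also leave open what the opposite configuration at the stereocentre would give when drawn on its own.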